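The source may hold more compounds than are shown below. What is called first, only, known or untested is meant among the compounds shown, and "the series" means these compounds.

Measured so far:
- compound 1, `CC1(C)N=C(N)N=C(N)N1c1ccccc1F`, with 4.39 in an assay on isolated protein for inhibition of Dihydrofolate reductase (Mus musculus), at pH 7.20; a higher number here means a more potent compound, by a factor of ten per unit of this negative logarithm, a lower number a less potent compound
- compound 2, `CSc1ccccc1N1C(N)=NC(N)=NC1(C)C`, with 2.48 in this assay

Compound 2 stands lowest of the two numbers; its nearest neighbour is compound 1, and the change is a number 1.91 log units lower from compound 1 to compound 2 (beyond the scatter), a large drop for a single swap on an aromatic carbon. Compound 3, `CC1(C)N=C(N)N=C(N)N1c1ccccc1C(F)(F)F`, has not yet been measured. It differs from compound 2 by trifluoromethyl in place of methylsulfanyl on an aromatic carbon.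

Going by the values given here, only one measured step bears on this change: a number 1.91 log units lower from compound 1 to compound 2 (beyond the scatter), which shows that putting methylsulfanyl in place of fluoro cost a great deal. Among the compounds with values here, compound 3 removes that methylsulfanyl, which is the part of the change that the data speak to, but the trifluoromethyl that enters appears in no measured compound, so its effect is unknown. The expectation is therefore a recovery of part, not all, of the loss seen between compound 1 and compound 2: an estimated step of a number 0.82 log units higher from compound 2 to compound 3 (beyond the scatter). For compound 3 the estimate in this assay is 3.3, expected to fall between 2.3 and 4.4.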

Compound 3, logarithm of the reciprocal of the active concentration, log(1/C): 3.03
Compound 3: middle estimate off by 0.27 log units, on the high side; measured number inside the range.
By their numbers in this assay, from the lowest: compound 2; then compound 3; then compound 1.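

In this assay, trifluoromethyl in place of methylsulfanyl gives a number 0.55 log units higher from compound 2 to compound 3 (beyond the scatter), so the two larger groups tried at this position are not equivalent. Trifluoromethyl has more heavy atoms than methylsulfanyl, yet compound 3 stands above compound 2, which means that across these three compounds the number does not simply fall as the group gets bigger. Even so, the change from fluoro to trifluoromethyl gives a number 1.36 log units lower from compound 1 to compound 3 (beyond the scatter), so the loss seen with methylsulfanyl is only partly recovered and compound 1 remains the highest of the three.

Nothing among the data shown explains why these groups rank as they do. Going by these compounds alone, with only three groups at one position, it remains open where a hydrogen, a chlorine, a methoxy group or an amine would fall in this order, and whether any group here could stand above fluoro.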